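Methyl on the fused core: compound 4 in a thienyl series

The source may report more compounds than this note shows. Statements on the series, on what has been measured and on what is new or still open speak of the compounds shown alone.

Measured so far in a functional assay on cells (Melanoma cell, Homo sapiens) for inhibition; on this read-out higher numbers stand for weaker inhibition of growth and lower numbers for stronger inhibition of growth:
compound 1 `Cc1cn2c(/C=N/NC(=N)N)c(-c3ccsc3)nc2s1`: 19500 nM
compound 2 `N=C(N)N/N=C/c1c(-c2ccsc2)nc2sccn12`: 31600 nM
compound 3 `N=C(N)N/N=C/c1c(-c2cccs2)nc2sccn12`: 28800 nM

Three compounds share the same guanidine hydrazone arm on a fused two-ring core and differ in two places. Compound 2 and compound 1 differ by methyl in place of hydrogen on an aromatic carbon; the step is a 1.6-fold lower number from compound 2 to compound 1 (0.21 log units; within the scatter). Compound 2 and compound 3 have the same atoms joined differently, (thiophen-2-yl in place of thiophen-3-yl on an aromatic carbon); the step is a 1.1-fold lower number from compound 2 to compound 3 (0.04 log units; within the scatter). All three numbers lie close together, and no ranking among them is supported.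

Compound 4 `Cc1cn2c(/C=N/NC(=N)N)c(-c3cccs3)nc2s1` is not yet measured. It differs from compound 3 by methyl in place of hydrogen on an aromatic carbon. This is the same change as that from compound 2 to compound 1: the "place" of the methyl reads word for word the same in both cases, on an aromatic carbon of the five-membered ring with one nitrogen and one sulfur, next to the ring sulfur, two ring bonds from the ring nitrogen. What differs between the two pairs is only the thiophen-2-yl in compound 3 and compound 4 against the thiophen-3-yl in compound 2 and compound 1, as given above.

In this assay, among the compounds with values here, the step from compound 3 to compound 4 is expected to be about a 1.5-fold lower number from compound 3 to compound 4 (0.18 log units; within the scatter), resting on the single earlier instance, a 1.6-fold lower number from compound 2 to compound 1 (0.21 log units; within the scatter), and on compound 3 at 28800 nM. Compound 4 is therefore estimated at 19000 nM, with a range of 9000 nM to 40000 nM. With one prior example the expected step is small and may not rise above repeat-measurement scatter.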

Compound 4, concentration for total growth inhibition: 5890 nM
Beside the measured number, compound 4's estimate is 3.2-fold (0.51 log units) above it; measured number below the stated range.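

In this assay, methyl in place of hydrogen on an aromatic carbon gives a 4.9-fold lower number from compound 3 to compound 4 (0.69 log units; beyond the scatter), and the size of this step does not carry over from the thiophen-3-yl pair to the thiophen-2-yl pair: the same change on two cores in this assay, a 1.6-fold lower number (0.21 log units; within the scatter) from compound 2 to compound 1 and a 4.9-fold lower number (0.69 log units; beyond the scatter) from compound 3 to compound 4, 3.0-fold (0.48 log units) apart, beyond the scatter of two such steps. Read the other way, with the methyl present, thiophen-2-yl in place of thiophen-3-yl gives a 3.3-fold lower number from compound 1 to compound 4 (0.52 log units; beyond the scatter), so the two changes do not act independently of each other in these four compounds: the same change on two cores in this assay, a 1.1-fold lower number (0.04 log units; within the scatter) from compound 2 to compound 3 and a 3.3-fold lower number (0.52 log units; beyond the scatter) from compound 1 to compound 4, 3.0-fold (0.48 log units) apart, beyond the scatter of two such steps. This shows that the step for one change depends on which thienyl group the core carries, but it rests on a single comparison of two pairs and does not show why they differ, nor does it give a rule for any other core.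

The compounds shown leave open whether an ethyl or a chlorine on the same aromatic carbon would follow the methyl, and whether a phenyl or a furan-2-yl in place of the thienyl group would give a step of the size seen with thiophen-2-yl or of the size seen with thiophen-3-yl. They also leave open whether the step survives when a simple amine replaces the guanidine hydrazone arm.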